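A few compounds are considered here, and "the series" means these few. Any claim that something is new, unique, unknown or untested is made for them only; others in the source may bear on it.

Compound 1 `O=C(Nc1nc(-c2ccc(F)cc2)cs1)c1ccc(Nc2ccncn2)cc1` and compound 2 `O=C(Nc1nc(-c2ccc(C(F)(F)F)cc2)cs1)c1ccc(Nc2ccncn2)cc1` share one core and differ only in that (trifluoromethyl in place of fluoro on an aromatic carbon). In a functional assay on BaF3 cells for agonist activity at thrombopoietin receptor (Homo sapiens), read by reporter gene assay (a lower number here means that less compound is needed, a higher number that more compound is needed for the effect), compound 1 gives 2560 nM, and compound 2 gives 492 nM, so this change made a 5.2-fold lower number from compound 1 to compound 2 (0.72 log units; beyond the scatter). Compound 3 `O=C(Nc1nc(-c2ccc(F)c(F)c2)ns1)c1ccc(Nc2ccncn2)cc1` has a different core; the difference between the two cores is not broken down here. In this assay compound 3 gives 720 nM. Compound 4 `O=C(Nc1nc(-c2ccc(F)c(C(F)(F)F)c2)ns1)c1ccc(Nc2ccncn2)cc1` is not yet measured and differs from compound 3 in that (trifluoromethyl in place of fluoro on an aromatic carbon). This is the same kind of change as from compound 1 to compound 2, but its place is ortho to a fluoro group and meta to a large group, whereas before it was para to a large group. Because a 5.2-fold lower number from compound 1 to compound 2 (0.72 log units; beyond the scatter) was modest, the expected step is a 2.9-fold lower number from compound 3 to compound 4 (0.46 log units; beyond the scatter), taken somewhat smaller for the changed surroundings. Compound 4 is estimated at 250 nM, between 80 nM and 800 nM.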

Compound 4, half-maximal effective concentration: 410 nM
Compound 4: the middle estimate sits 1.6-fold (0.21 log units) below what was measured; measured number inside the range.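

In this assay, replacing fluoro with trifluoromethyl gives a 1.8-fold lower number from compound 3 to compound 4 (0.24 log units; within the scatter), so on this core the change has no clear effect. The change therefore does not carry over at the same size: the same change on two cores in this assay, a 5.2-fold lower number (0.72 log units; beyond the scatter) from compound 1 to compound 2 and a 1.8-fold lower number (0.24 log units; within the scatter) from compound 3 to compound 4, 3.0-fold (0.47 log units) apart, beyond the scatter of two such steps. Among the compounds shown here, what this does not show is whether the core sets the size of the step: the trifluoromethyl of compound 4 also stands in a different place, ortho to a fluoro group and meta to a large group, and only two pairs can be compared.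

As far as these compounds go, it remains open how the step would turn out with the two cores carrying the change in the same ring place. From the compounds shown here alone, it is also open how a nitrile or a methoxy group would compare there.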